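Compound 1 and its fluoro counterpart, compound 4

A few compounds are considered here, and "the series" means these few. Any claim that something is new, unique, unknown or untested is made for them only; others in the source may bear on it.

Measured in an ADME assay on microsomes from liver (Rattus norvegicus) for metabolic stability, read by LC-MS, with a stated time of 1 h, at 37 degrees C, tested at 4 uM; a higher number here means that more of the compound is left, a lower number that less of the compound is left
Compound 1 `O=C(O)c1cc(-c2cccc(COc3ccc4c(c3)CN(C3CCCC3)C4=O)c2)ccc1O` gives 9%
Compound 2 `CC(C)CCn1sc2cc(OCc3cccc(-c4ccc(Cl)c(C(=O)O)c4)c3)ccc2c1=O` gives 92%
Compound 3 `O=C(O)c1cc(-c2cccc(COc3ccc4c(=O)n(C5CCCC5)sc4c3)c2)ccc1F` gives 71%

Compound 1 stands lowest of the three, and both others lie beyond the scatter above it. In compound 4 `O=C(O)c1cc(F)cc(-c2cccc(COc3ccc4c(c3)CN(C3CCCC3)C4=O)c2)c1` the core of compound 1 stays, and 3-carboxy-5-fluorophenyl stands in place of 3-carboxy-4-hydroxyphenyl on an aromatic carbon 3-carboxy-5-fluorophenyl in place of 3-carboxy-4-hydroxyphenyl on an aromatic carbon in the structure. For the measured compounds named here, no measured pair shows this change alone. Compound 3 at 71% also has no hydroxy group, but its core differs, so it is only a loose guide. In this assay the expected step is a number 19 percentage points higher from compound 1 to compound 4 (beyond the scatter) upward, with wide uncertainty. Compound 4 is estimated at 28% (10% to 60%).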

Compound 4, percent of the compound remaining: 55%
For compound 4 the middle estimate is 27 percentage points below the measured one; the measured number falls inside the stated range.
By their numbers in this assay, from the lowest: compound 1; then compound 4; then compound 3; then compound 2.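

In this assay, for the compounds shown here, putting 3-carboxy-5-fluorophenyl in place of 3-carboxy-4-hydroxyphenyl on the core of compound 1 gives a number 46 percentage points higher from compound 1 to compound 4 (beyond the scatter) and is the first change seen alone on an unchanged core. It shows that this group by itself, with the core held fixed, moves the percent remaining by a large amount.

Going by these compounds, the change takes away the hydroxy group and brings in the fluorine together, so it remains open which of the two carries the step and how a methoxy group or an amine would behave on this ring. Nothing shown gives a reason for the step.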